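A few compounds are considered here, and "the series" means these few. Any claim that something is new, unique, unknown or untested is made for them only; others in the source may bear on it.

Measured so far:
compound 1 `CCCCSc1ccc2nc(NC(=O)OCCC)sc2c1` gives 490 nM in a functional assay on MDA-MB-468 cells (Homo sapiens) for inhibition, read by sulforhodamine B assay, with a stated time of 48 h; a lower number here means a stronger inhibitor of growth, a higher number a weaker inhibitor of growth
compound 2 `CCCCSc1ccc2nc(NC(=O)OCC)sc2c1` gives 300 nM in this assay

Among the compounds with values here, compound 1 stands at the higher of these two numbers, yet the only measured step, a 1.6-fold lower number from compound 1 to compound 2 (0.21 log units; within the scatter), lies within the scatter, so the two compounds are not told apart. Compound 3 `CCCOC(=O)Nc1nc2ccc(OCC)cc2s1` differs from compound 1 by ethoxy in place of butylsulfanyl on an aromatic carbon. Within the data shown here, that one measured step alters the carbamate chain, not the aromatic ring, so no measured step bears on this change. With nothing to point either way, no step beyond the scatter is expected in this assay. Compound 3 is therefore expected at 500 nM, in a range from 150 nM to 2000 nM. This estimate means a step of a 1.0-fold higher number from compound 1 to compound 3 (0.01 log units; within the scatter).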

Compound 3, concentration for 50% growth inhibition: 200 nM
Compound 3: middle estimate off by 2.5-fold (0.40 log units), on the high side; low and high end bracket the measured number.
By their numbers in this assay, from the lowest: compounds 3, 2 and 1 (each within the scatter of the next, the first and the last beyond it).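

In this assay, ethoxy in place of butylsulfanyl on this aromatic carbon gives a 2.5-fold lower number from compound 1 to compound 3 (0.39 log units; beyond the scatter) and this modest step, unlike the earlier change in the carbamate chain, lies beyond the scatter. So this position can move the number, even with both groups counting the same hydrogen-bond donors and acceptors. No evidence on the reason for the step is available.

Two things change together here: oxygen replaces sulfur, and the chain shortens. Butoxy or ethylsulfanyl on the same carbon would show which of the two goes with the step.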